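Swapping the phenyl substituent on the triazole: compound 3

The source may hold more compounds than are shown below. What is called first, only, known or untested is meant among the compounds shown, and "the series" means these compounds.

Compound 1, `CC1(C)[C@H]2CC[C@]1(C)N(Cc1cn(-c3ccc(F)cc3)nn1)C(=O)C2`, in a functional assay on HepG2 cells (Homo sapiens) for inhibition, read by MTT assay, with a stated time of 24 h (a lower number here means a stronger inhibitor, a higher number a weaker inhibitor), gives 90 nM.
Compound 2, `CC1(C)[C@H]2CC[C@]1(C)N(Cc1cn(-c3cccc(Cl)c3)nn1)C(=O)C2`, in this assay gives 60 nM.

Compound 2 has the lowest of the two numbers, with compound 1 nearest; the step of a 1.5-fold lower number from compound 1 to compound 2 (0.18 log units; within the scatter) lies within the scatter. Compound 3, `Cc1ccccc1-n1cc(CN2C(=O)C[C@@H]3CC[C@@]2(C)C3(C)C)nn1`, differs from compound 2 in one place: 2-methylphenyl in place of 3-chlorophenyl on an aromatic nitrogen. Among the measured compounds shown here, the one measured step bears on it only loosely, since it exchanged one phenyl substituent for another and moved the number little. A step of similar size, no larger than the scatter, is therefore expected for a 1.2-fold higher number from compound 2 to compound 3 (0.07 log units; within the scatter). Compound 3 is estimated at 70 nM, within 30 nM to 160 nM.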

Compound 3, half-maximal inhibitory concentration: 150 nM
The estimate for compound 3 lay 2.1-fold (0.33 log units) below the measured number, within the range that was stated.
By their numbers in this assay, from the lowest: compounds 2, 1 and 3 (each within the scatter of the next, the first and the last beyond it).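

Among the compounds shown here, with 2-methylphenyl in place of 3-chlorophenyl, this assay shows a 2.5-fold higher number from compound 2 to compound 3 (0.40 log units; beyond the scatter), the first step at this aromatic nitrogen to pass the scatter, so the choice of phenyl substituent here can change the number. Measured against the 4-fluorophenyl group, the same 2-methylphenyl group gives a 1.7-fold higher number from compound 1 to compound 3 (0.22 log units; within the scatter) and stays within the scatter. Nothing shown explains either step.

Both the substituent and its place on the phenyl differ between compound 2 and compound 3, so their contributions remain unseparated. From the compounds shown here alone, how 2-chlorophenyl, 3-methylphenyl or an amine on the phenyl would read also stays open.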